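The compounds below may be only part of what the source reports. "The series", "measured", "known", "first", "only" and "open" are said of these compounds alone.

The compounds measured in a functional assay on MDA-MB-231 cells (Homo sapiens) for cytotoxicity, read by MTT assay, with a stated time of 48 h (on this read-out higher numbers stand for weaker inhibition and lower numbers for stronger inhibition), are:
compound 1 `O=C(/C=C/c1ccc2c(c1)B(O)OC2)c1ccccc1`, 2300 nM;
compound 2 `Nc1ccc(C(=O)/C=C/c2ccc3c(c2)B(O)OC3)cc1`, 25800 nM;
compound 3 `O=C(/C=C/c1ccc2c(c1)B(O)OC2)c1ccccc1F`, 2200 nM.

Compound 3 has the lowest number of the three; compound 1 sits within the scatter of it, while compound 2 lies far apart, as a 12-fold lower number from compound 2 to compound 3 (1.07 log units; beyond the scatter) shows. Compound 4 `Nc1cccc(C(=O)/C=C/c2ccc3c(c2)B(O)OC3)c1` differs from compound 3 in one place: 3-aminophenyl in place of 2-fluorophenyl on a carbonyl carbon. Among the measured compounds shown here, two measured steps bear on this change. The step of a 1.0-fold lower number from compound 1 to compound 3 (0.02 log units; within the scatter) stays within the scatter, whereas an 11-fold higher number from compound 1 to compound 2 (1.05 log units; beyond the scatter) is large, with the amino group in the 4-aminophenyl arrangement. For the measured compounds named here, no 3-aminophenyl analogue has been measured, so the size of the shift is uncertain, but a rise beyond the scatter is expected. In this assay compound 4 is expected to give 8000 nM, with a range from 2500 nM to 25000 nM. The expected step is a 3.6-fold higher number from compound 3 to compound 4 (0.56 log units; beyond the scatter).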

Compound 4, half-maximal inhibitory concentration: 3200 nM
Beside the measured number, compound 4's estimate is 2.5-fold (0.40 log units) above it, and the stated range covers the measured number.
By their numbers in this assay, from the lowest: compounds 3, 1 and 4 (each within the scatter of the next); then compound 2.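

In this assay, the two amino isomers do not behave alike (an 8.1-fold lower number from compound 2 to compound 4 (0.91 log units; beyond the scatter)), so the place of the amino group on the phenyl matters here. The 3-aminophenyl group stays within the scatter of the unsubstituted phenyl (a 1.4-fold higher number from compound 1 to compound 4 (0.14 log units; within the scatter)) and of 2-fluorophenyl (a 1.5-fold higher number from compound 3 to compound 4 (0.16 log units; within the scatter)), which shows that an amino group does not always bring the large rise seen with compound 2. Nothing available here accounts for this difference.

Going by these compounds, what a hydroxyl or a dimethylamino group would give on this phenyl remains open, as does whether the gap between the amino isomers holds in other cell lines.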